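Amino Substituent on a Boron-Containing Chalcone Scaffold

The source may report more compounds than this note shows. Statements on the series, on what has been measured and on what is new or still open speak of the compounds shown alone.

Compound 1 `O=C(/C=C/c1ccc2c(c1)B(O)OC2)c1ccccc1` was tested in a toxicity assay on MCF-10A cells (Homo sapiens) for cytotoxicity, read by MTT assay, with a stated time of 48 h (on this read-out lower numbers stand for stronger inhibition and higher numbers for weaker inhibition), where compound 1 gives 15900 nM. Among the three measured compounds it stands second highest: compound 2 `CSc1ccc(C(=O)/C=C/c2ccc3c(c2)B(O)OC3)cc1` gives 7400 nM, and compound 3 `O=C(/C=C/c1ccc2c(c1)B(O)OC2)c1ccc(O)cc1` gives 24800 nM. Two single changes at the same place have been measured: a 1.6-fold higher number from compound 1 to compound 3 (0.19 log units; within the scatter), while a 2.1-fold lower number from compound 1 to compound 2 (0.33 log units; beyond the scatter). Compound 4 `Nc1ccc(C(=O)/C=C/c2ccc3c(c2)B(O)OC3)cc1` carries one change from compound 1: amino in place of hydrogen on an aromatic carbon. The hydroxy change is the nearer comparison, and that step stayed within the scatter; only the methylsulfanyl step went beyond it. A small step is therefore expected, a 1.3-fold higher number from compound 1 to compound 4 (0.10 log units; within the scatter), most likely within the scatter. Compound 4 is estimated at 20000 nM, in a range from 9000 nM to 45000 nM in this assay.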

Compound 4, half-maximal inhibitory concentration: 19900 nM
Compound 4: middle estimate off by 1.0-fold (0.00 log units), on the high side; the measured number falls inside the stated range.
By their numbers in this assay, from the lowest: compound 2; then compounds 1, 4 and 3 (each within the scatter of the next).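

In this assay, amino at this place on the ring cannot be told apart from hydrogen (a 1.3-fold higher number from compound 1 to compound 4 (0.10 log units; within the scatter)) or from hydroxy (a 1.2-fold lower number from compound 3 to compound 4 (0.10 log units; within the scatter)), so three of the four groups now sit together. Methylsulfanyl alone stands apart from amino (a 2.7-fold higher number from compound 2 to compound 4 (0.43 log units; beyond the scatter)), though only modestly. Nothing available here explains this grouping.

Open, going by these compounds, is whether methoxy, which has oxygen where methylsulfanyl has sulfur, would follow methylsulfanyl or join the other three. Dimethylamino or a carboxylic acid at this place could test the same question.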